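This account rests on a few compounds, and the source may have more. Where it says the series, first, only, none or still open, it means among the compounds named here.

Working notes on the series. Compound 1 `CC(=O)c1cccc(-c2ccc(C(=O)N(Cc3cccc(OCCCCCC(=O)O)c3)C(C)C)cc2)c1` and compound 2 `CCOc1cccc(-c2ccc(C(=O)N(Cc3cccc(OCCCCCC(=O)O)c3)C(C)C)cc2)c1` share one core and differ at a single aromatic carbon, where compound 2 carries ethoxy in place of acetyl. In an ADME assay on HepG2 cells (Homo sapiens) for cytotoxicity, read by CellTiter-Glo and resazurin assay, with a stated time of 72 h (a lower number here means that less compound is needed, a higher number that more compound is needed for the effect), compound 1 gives only a limit, > 26000 nM. In this assay compound 2 likewise gives only a limit, > 20800 nM. The step that the two limits leave unreadable from compound 1 to compound 2 is therefore unreadable, since both values sit at the ceiling of the measurement (the limit of > 20800 nM in this assay, at which 1 of the 2 values shown sits, (the limit of > 26000 nM in this assay, at which 1 of the 2 values shown sits)). Compound 2 thus stands without a number of its own in this assay; all that is known is the limit it shares with compound 1.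

Compound 3 `COc1cc(OC)cc(-c2ccc(C(=O)N(Cc3cccc(OCCCCCC(=O)O)c3)C(C)C)cc2)c1` is the next member. Its change from compound 2 is 3,5-dimethoxyphenyl in place of 3-ethoxyphenyl on an aromatic carbon. For the measured compounds named here, the only measured step, from compound 1 to compound 2, could not be sized, so no read on direction or magnitude is available for this change. The expectation is that compound 3 again reaches only the ceiling in this assay. For compound 3 the estimated value in this assay is 30000 nM, with a range from 10000 nM to 100000 nM. The step that the limit leaves unreadable from compound 2 to compound 3 is expected to stay within the scatter, most likely again recorded only as a limit.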

Compound 3, half-maximal effective concentration: > 26000 nM
Compound 3: a limit, no number (the forecaster's own chance of this, stated with the estimate: 80%); the middle value lies beyond the limit too.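

In this assay compound 3 gives only a limit, > 26000 nM. For the compounds shown here, compound 1 and compound 2 are also held at limits, so no step among compound 1, compound 2 and compound 3 can be read. The compounds shown leave open whether any of them has a measurable half-maximal effective concentration here, and how their true values compare.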